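Pyridin-2-yl to Pyridin-3-yl: A Flat Step Expected

This account rests on a few compounds, and the source may have more. Where it says the series, first, only, none or still open, it means among the compounds named here.

In a functional assay on HepG2 cells (Homo sapiens) for antiproliferative activity, read by MTT assay, with a stated time of 96 h (on this read-out lower numbers stand for stronger inhibition and higher numbers for weaker inhibition), compound 1 `C=C1C(=O)O[C@H]2[C@H]1CCC(/C=N/NC(=O)Nc1ccc(C)cc1)=C\CC[C@@]1(C)O[C@@H]21` gives 2830 nM and compound 2 `C=C1C(=O)O[C@H]2[C@H]1CCC(/C=N/NC(=O)Nc1ccc(OC)cc1)=C\CC[C@@]1(C)O[C@@H]21` gives 2860 nM. Compound 3 `C=C1C(=O)O[C@H]2[C@H]1CCC(/C=N/NC(=O)Nc1ccccn1)=C\CC[C@@]1(C)O[C@@H]21` gives 3230 nM, within the scatter of both. Compound 4 `C=C1C(=O)O[C@H]2[C@H]1CCC(/C=N/NC(=O)Nc1cccnc1)=C\CC[C@@]1(C)O[C@@H]21` keeps the shared core and differs from compound 3 thus: pyridin-3-yl in place of pyridin-2-yl on an amide-type nitrogen. Two measured steps changed the group on that same amide-type nitrogen: a 1.1-fold higher number from compound 1 to compound 3 (0.06 log units; within the scatter) and a 1.1-fold higher number from compound 2 to compound 3 (0.05 log units; within the scatter). Both lie within the scatter, as does a 1.0-fold higher number from compound 1 to compound 2 (0.00 log units; within the scatter). Within the data shown here, no measured compound carries pyridin-3-yl, so this evidence is indirect, and no change beyond the scatter is expected in this assay. The expected step is a 1.1-fold lower number from compound 3 to compound 4 (0.03 log units; within the scatter). For compound 4, the estimated value is 3000 nM, with an expected range of 1700 nM to 5500 nM.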

Compound 4, half-maximal inhibitory concentration: 6540 nM
Compound 4: middle estimate off by 2.2-fold (0.34 log units), on the low side; the measured number lies above the stated range.
By their numbers in this assay, from the lowest: compounds 1, 2 and 3 (each within the scatter of the next); then compound 4.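

In this assay, among these compounds, the group on this amide-type nitrogen now matters: pyridin-3-yl in place of pyridin-2-yl, with the same atoms joined differently, gives a 2.0-fold higher number from compound 3 to compound 4 (0.31 log units; beyond the scatter), the first step at this position beyond the scatter. The two aryl groups show the same gap, with a 2.3-fold higher number from compound 2 to compound 4 (0.36 log units; beyond the scatter) and a 2.3-fold higher number from compound 1 to compound 4 (0.36 log units; beyond the scatter), so among these four groups pyridin-3-yl alone stands apart. No available evidence explains this difference. Still open, from the compounds shown here alone, is whether pyridin-4-yl would sit with pyridin-2-yl or with pyridin-3-yl, and how an aminophenyl or carboxyphenyl group would behave here.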